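Butyl ester with pivaloyl thioester: expected half-life

A few compounds are considered here, and "the series" means these few. Any claim that something is new, unique, unknown or untested is made for them only; others in the source may bear on it.

Working notes on a small set of glutamine-derived thioesters examined in an ADME assay on isolated protein for metabolic stability, with Cocaine esterase (Homo sapiens) as the target; on this read-out lower numbers stand for a shorter-lived compound and higher numbers for a longer-lived compound. Compound 1 `CCCCOC(=O)[C@@H](N)CCC(=O)NCCSC(=O)c1ccccc1` gives 0.167 h in this assay. Compound 2 `CCOC(=O)[C@@H](N)CCC(=O)NCCSC(=O)C(C)(C)C` gives 0.167 h in this assay, level with compound 1 at the digits shown; the pair shows no change within the scatter, so no ordering between them is claimed.

Compound 3 `CCCCOC(=O)[C@@H](N)CCC(=O)NCCSC(=O)C(C)(C)C` is not yet measured. Against compound 2 the change is ethyl in place of hydrogen on a saturated chain carbon, two bonds along the chain from an oxygen next to a carbonyl group; read one bond further out it is ethoxy to butoxy. Compound 1 already carries the butoxy ester and sits at 0.167 h in this assay, the same figure compound 2 gives with the ethoxy ester, so no step beyond the scatter is expected from compound 2 to compound 3 in this assay. The step is estimated as no change at the digits printed from compound 2 to compound 3 (within the scatter) in this assay. Compound 3 is therefore expected at 0.167 h in this assay, within 0.08 h to 0.35 h.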

Compound 3, half-life: 0.167 h
For compound 3 middle estimate and measured number coincide at the digits printed; low and high end bracket the measured number.
By their numbers in this assay, from the lowest: compounds 1, 2 and 3 (each within the scatter of the next).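

In this assay, ethyl in place of hydrogen on a saturated chain carbon, two bonds along the chain from an oxygen next to a carbonyl group, read also as ethoxy to butoxy, gives no change at the digits printed from compound 2 to compound 3 (within the scatter) with the tert-butyl thioester held constant, so the ester change can now be read on its own rather than alongside a second difference. Going by these compounds alone, compound 3 also provides the first comparison confined to the thioester: tert-butyl in place of phenyl on a carbonyl carbon gives no change at the digits printed from compound 1 to compound 3 (within the scatter) with the butoxy ester held constant. Nothing available here bears on why neither change moves the half-life beyond the scatter.

These two steps cover only ethoxy and butoxy esters and only tert-butyl and phenyl thioesters, so they do not extend to other replacements at either place. Open questions are whether a carboxylic acid in place of the butoxy ester, a chain longer than butyl on the ester oxygen, or an amide in place of the thioester would give a half-life beyond the scatter of these compounds.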